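Pyridyl swap on the fused core: working notes

The source may report more compounds than this note shows. Statements on the series, on what has been measured and on what is new or still open speak of the compounds shown alone.

Measured so far in a functional assay on prostate cells (Homo sapiens) for antiproliferative activity; a lower number here means a stronger inhibitor of growth, a higher number a weaker inhibitor of growth:
Compound 1, `Cc1sc2nc(-c3ccccn3)c(/C=N/NC(=N)N)n2c1C`: 22400 nM
Compound 2, `N=C(N)N/N=C/c1c(-c2ccccn2)nc2sc(Cl)cn12`: 9330 nM
Compound 3, `N=C(N)N/N=C/c1c(-c2ccncc2)nc2sc(Cl)cn12`: 17400 nM

Compound 1 stands highest of the three numbers. Against compound 3 the gap is within the scatter, so no order between those two can be read; against compound 2 the gap is beyond the scatter, so compound 1 is the weaker growth inhibitor of that pair.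

The step under consideration leads from compound 1 to compound 4, `Cc1sc2nc(-c3ccncc3)c(/C=N/NC(=N)N)n2c1C`. The change is pyridin-4-yl in place of pyridin-2-yl on an aromatic carbon.

Within the data shown here, one measured step bears on it directly, the same exchange of pyridyl groups on the closely related core that carries chlorine rather than the two methyl groups: a 1.9-fold higher number from compound 2 to compound 3 (0.27 log units; within the scatter). That step was small and within the scatter, pointing, if anywhere, towards a somewhat higher number. Among the measured compounds shown here, with only one such pair available, no further pattern can be claimed.

Compound 4 is therefore expected to give a number close to that of compound 1, with a mild drift upward, estimated at 35000 nM within a range of 15000 nM to 80000 nM. The step that this estimate means, a 1.6-fold higher number from compound 1 to compound 4 (0.19 log units; within the scatter), is expected to remain within the scatter.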

Compound 4, concentration for 50% growth inhibition: 55000 nM
Compound 4: middle estimate off by 1.6-fold (0.20 log units), on the low side, within the range that was stated.
By their numbers in this assay, from the lowest: compounds 2, 3 and 1 (each within the scatter of the next, the first and the last beyond it); then compound 4.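

In this assay, pyridin-4-yl in place of pyridin-2-yl on the core with the two methyl groups gives a 2.5-fold higher number from compound 1 to compound 4 (0.39 log units; beyond the scatter), so this exchange at this position now produces a step that can be read, which the pair on the chlorine-bearing core did not. The direction is the same on both cores, and the two steps do not differ in size beyond what repeated measurement allows: the same change on two cores in this assay, a 1.9-fold higher number (0.27 log units; within the scatter) from compound 2 to compound 3 and a 2.5-fold higher number (0.39 log units; beyond the scatter) from compound 1 to compound 4, 1.3-fold (0.12 log units) apart, within the scatter of two such steps. Across these two pairs, the only ones available, pyridin-2-yl goes with the lower number and neither pair goes against that, although the step on the chlorine-bearing core taken alone stays within the scatter.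

The compounds shown leave open how pyridin-3-yl or a plain phenyl would stand at this position against pyridin-2-yl, so it remains unsettled whether the placing of the ring nitrogen or its mere presence goes with these numbers. They also leave open whether the same order holds on cores carrying other groups in place of the chlorine or the two methyl groups, such as a methoxy group or a carboxylic acid.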